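The source may report more compounds than this note shows. Statements on the series, on what has been measured and on what is new or still open speak of the compounds shown alone.

Compound 1 `COc1nc(C2CCCCC2)ccc1[C@@H](c1ccccc1)[C@@](O)(CCN(C)C)c1cccc2ccccc12` gives 57.7 ug/mL in a toxicity assay on HeLa cells (Homo sapiens) for cytotoxicity; on this read-out higher numbers stand for lower toxicity in this test and lower numbers for higher toxicity in this test. Compound 2 `COc1nc(-c2ccc(OC(F)(F)F)cc2)ccc1[C@@H](c1ccccc1)[C@@](O)(CCN(C)C)c1cccc2ccccc12` in this assay gives only a limit, > 64 ug/mL. Among the compounds with values here, the one step measured so far, an at least 1.1-fold higher number from compound 1 to compound 2 (0.04 log units; that floor lies within the scatter), runs up to the limit described by the limit of > 64 ug/mL in this assay, at which 1 of the 2 values shown sits. Compound 3 `COc1nc(-c2cccc(F)c2)ccc1[C@@H](c1ccccc1)[C@@](O)(CCN(C)C)c1cccc2ccccc12` follows from compound 2 by the change (3-fluorophenyl in place of 4-(trifluoromethoxy)phenyl on an aromatic carbon). Within the data shown here, no measured step covers a change between two aryl groups of this kind, and the one step known is within the scatter, so for compound 3 no step beyond the scatter is expected in this assay, meaning an at least 1.0-fold lower number from compound 2 to compound 3 (0.02 log units; that floor lies within the scatter). Compound 3 is therefore estimated at 60 ug/mL, with a range from 30 ug/mL to 120 ug/mL.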

Compound 3, half-maximal cytotoxic concentration: 62.8 ug/mL
Beside the measured number, compound 3's estimate is 1.0-fold (0.02 log units) below it, and the stated range covers the measured number.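

In this assay, the place next to the ring nitrogen now holds a third group, and the change from a saturated ring to 3-fluorophenyl stays small: a 1.1-fold higher number from compound 1 to compound 3 (0.04 log units; within the scatter). Compound 2 gives only a limit of the assay: the limit of > 64 ug/mL in this assay, at which 1 of the 3 values shown sits. The step read against that limit is an at least 1.0-fold lower number from compound 2 to compound 3 (0.00 log units; that floor lies within the scatter), so cyclohexyl, 3-fluorophenyl and 4-(trifluoromethoxy)phenyl are not told apart here. Still open, as far as these compounds go, is whether an amine, a carboxylic acid or a longer chain at this place would move the number in this assay beyond the scatter.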